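A few compounds are considered here, and "the series" means these few. Any claim that something is new, unique, unknown or untested is made for them only; others in the source may bear on it.

Measured so far in a functional assay on HepG2 cells (Homo sapiens) for cytotoxicity, read by MTT assay, with a stated time of 72 h; on this read-out lower numbers stand for stronger inhibition and higher numbers for weaker inhibition:
compound 1 `COc1ccc2ccc(=O)oc2c1C1=NNC(c2ccc(C)cc2)C1` — 43 nM
compound 2 `COc1ccc2ccc(=O)oc2c1C1=NNC(c2ccc(SC)cc2)C1` — 10 nM
compound 3 `COc1ccc2ccc(=O)oc2c1C1=NN(c2ccccc2)C(c2ccc(SC)cc2)C1` — 78 nM

Compound 3 gives the highest number of the three in this assay; its gap to compound 1 lies within the scatter, its gap to compound 2 beyond it. Two single-point steps are on record: a 4.3-fold lower number from compound 1 to compound 2 (0.63 log units; beyond the scatter), and a 7.8-fold higher number from compound 2 to compound 3 (0.89 log units; beyond the scatter).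

Compound 4 `COc1ccc2ccc(=O)oc2c1C1=NN(c2ccccc2)C(c2ccc(C)cc2)C1` is not yet measured. Its difference from compound 3 is methyl in place of methylsulfanyl on an aromatic carbon. This is the reverse of the change behind a 4.3-fold lower number from compound 1 to compound 2 (0.63 log units; beyond the scatter), now made on the core that already carries phenyl on the ring nitrogen. That step is the one that bears on it. The other, a 7.8-fold higher number from compound 2 to compound 3 (0.89 log units; beyond the scatter), concerns the phenyl and not the methyl-to-methylsulfanyl exchange, so whether the exchange keeps its size when phenyl is present is not shown. Compound 4 is therefore expected to return a higher number than compound 3, by a step of about a 3.8-fold higher number from compound 3 to compound 4 (0.59 log units; beyond the scatter). The estimate for compound 4 in this assay is 300 nM, with a range from 100 nM to 900 nM.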

Compound 4, half-maximal inhibitory concentration: 51 nM
Compound 4: the middle estimate sits 5.9-fold (0.77 log units) above what was measured; measured number outside the range, below it.
By their numbers in this assay, from the lowest: compound 2; then compounds 1, 4 and 3 (each within the scatter of the next).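

In this assay, methyl in place of methylsulfanyl on the core carrying phenyl on the ring nitrogen gives a 1.5-fold lower number from compound 3 to compound 4 (0.18 log units; within the scatter), so the advantage of methylsulfanyl seen on the core of compound 1 does not carry over: the same change on two cores in this assay, a 4.3-fold lower number (0.63 log units; beyond the scatter) from compound 1 to compound 2 and a 1.5-fold higher number (0.18 log units; within the scatter) from compound 4 to compound 3, 6.6-fold (0.82 log units) apart, beyond the scatter of two such steps. The effect of phenyl on the ring nitrogen likewise depends on the group on the aromatic ring, with a 1.2-fold higher number from compound 1 to compound 4 (0.07 log units; within the scatter) when methyl is present: the same change on two cores in this assay, a 7.8-fold higher number (0.89 log units; beyond the scatter) from compound 2 to compound 3 and a 1.2-fold higher number (0.07 log units; within the scatter) from compound 1 to compound 4, 6.6-fold (0.82 log units) apart, beyond the scatter of two such steps. The two changes therefore do not add across these four compounds, and compound 2 stands apart from both of its single-change neighbours, compound 1 and compound 3.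

As far as these compounds go, whether methoxy or ethylsulfanyl in this position would behave like methylsulfanyl remains open. Also open, from the compounds shown here alone, is whether methyl or acetyl on the ring nitrogen would remove the methylsulfanyl step as phenyl does.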